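Amide nitrogen substituents: from compound 3 to compound 4

This account rests on a few compounds, and the source may have more. Where it says the series, first, only, none or still open, it means among the compounds named here.

Measured so far:
Compound 1 `COc1ccc2c(=O)c(/C=C/C(=O)Nc3ccc(C)cc3)coc2c1`; in a functional assay on Huh-7 cells (Homo sapiens) for inhibition, read by MTT assay, with a stated time of 48 h (on this read-out higher numbers stand for weaker inhibition and lower numbers for stronger inhibition), compound 1 reaches only the assay limit > 100000 nM.
Compound 2 `COc1ccc2c(=O)c(/C=C/C(=O)NCc3cccc(F)c3)coc2c1`; compound 2 gives 10100 nM in this assay.
Compound 3 `COc1ccc2c(=O)c(/C=C/C(=O)Nc3ccccc3)coc2c1`; compound 3 gives 9050 nM in this assay.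

Compound 3 holds the lowest of the two numbers, yet its neighbour compound 2 sits within the scatter: a 1.1-fold lower number from compound 2 to compound 3 (0.05 log units; within the scatter). Compound 1 stands apart at the limit (the limit of > 100000 nM in this assay, at which 1 of the 3 values shown sits).

Compound 4 `COc1ccc2c(=O)c(/C=C/C(=O)NCc3ccc(F)cc3)coc2c1` differs from compound 3 in one place: 4-fluorobenzyl in place of phenyl on an amide-type nitrogen. The step that bears on it is the exchange of phenyl for 3-fluorobenzyl, a 1.1-fold lower number from compound 2 to compound 3 (0.05 log units; within the scatter), which stayed within the scatter. A 4-fluorobenzyl is expected to behave like the 3-fluorobenzyl of compound 2, so no step beyond the scatter is expected, a 1.0-fold higher number from compound 3 to compound 4 (0.02 log units; within the scatter). Compound 4 is therefore estimated at 9500 nM, between 4000 nM and 25000 nM.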

Compound 4, half-maximal inhibitory concentration: 21000 nM
Beside the measured number, compound 4's estimate is 2.2-fold (0.34 log units) below it; the range from low to high includes it.
By their numbers in this assay, from the lowest: compounds 3 and 2 (each within the scatter of the next); then compound 4. At a limit, above all of these: compound 1.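

In this assay the benzyl substitution pattern now registers: a 2.1-fold higher number from compound 2 to compound 4 (0.32 log units; beyond the scatter) for a change confined to 3-fluorophenyl versus 4-fluorophenyl on the saturated chain carbon. Against phenyl on the amide-type nitrogen there is a 2.3-fold higher number from compound 3 to compound 4 (0.37 log units; beyond the scatter) for the 4-fluorobenzyl, whereas the 3-fluorobenzyl stayed within the scatter of phenyl. Compound 1 is held at a limit, so an at least 4.7-fold lower number from compound 1 to compound 4 (0.67 log units; beyond the scatter) reads only as a bound: the limit of > 100000 nM in this assay, at which 1 of the 4 values shown sits.

Open, going by these compounds, is how an unsubstituted benzyl or a longer chain such as 2-phenylethyl would compare on this nitrogen. Also open, on these data alone, is whether a chlorine or a methoxy group on the benzyl ring would follow the 4-fluorobenzyl or the 3-fluorobenzyl.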